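This account rests on a few compounds, and the source may have more. Where it says the series, first, only, none or still open, it means among the compounds named here.

Series notes. Compound 1 `CCCCCOC(=O)N1CCN(C(=O)[C@H](CCC(=O)O)NC(=O)c2cc(N3CCC(C(=O)N4CCCC4)CC3)nc(-c3ccccc3)n2)CC1`, compound 2 `CCCCCOC(=O)N1CCN(C(=O)[C@H](CCC(=O)O)NC(=O)c2cc(N3CCC(N4CCCC4)CC3)nc(-c3ccccc3)n2)CC1` and compound 3 `CCCCCOC(=O)N1CCN(C(=O)[C@H](CCC(=O)O)NC(=O)c2cc(N3CCC(OCCO)CC3)nc(-c3ccccc3)n2)CC1` share one core and differ only in the group on a saturated ring carbon. In an ADME assay on microsomes from liver (Homo sapiens) for metabolic stability (on this read-out lower numbers stand for a less stable compound and higher numbers for a more stable compound), compound 1 gives > 80%, which is a limit of the assay rather than a number. Compound 2 likewise gives > 80%, again a limit. Compound 3 stands at > 80%, also a limit and not a number. The three steps among the measured compounds, a step that the two limits leave unreadable from compound 1 to compound 2, a step that the two limits leave unreadable from compound 1 to compound 3 and a step that the two limits leave unreadable from compound 2 to compound 3, therefore carry no readable size. What is on record is the limit of > 80% in this assay, at which 3 of the 3 values shown sit.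

Compound 4 `CCCCCOC(=O)N1CCN(C(=O)[C@H](CCC(=O)O)NC(=O)c2cc(N3CCC(C(N)=O)CC3)nc(-c3ccccc3)n2)CC1` follows from compound 3 by carbamoyl in place of 2-hydroxyethoxy on a saturated ring carbon. Going by the values given here, no measured step covers this change. The steps that touch the same saturated ring carbon are all unreadable, so there is no size to carry over. With every measured value sitting at the limit, no step beyond the scatter in this assay is expected in either direction. The expected step is a step that the limit leaves unreadable from compound 3 to compound 4, within the scatter. Compound 4 is estimated at 85%, with a range from 70% to 97%, and is most likely to be reported once more as a limit.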

Compound 4, percent of the compound remaining: > 80%
Compound 4 ended at the assay's limit; the forecaster's own chance of this, stated with the estimate: 75%; the middle value is on the limit's open side.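

In this assay compound 4 gives > 80%, a limit and not a number. No new step can be read between compound 4 and compound 1, compound 2 or compound 3: the limit of > 80% in this assay, at which 4 of the 4 values shown sit.

The compounds shown leave open whether the groups on the saturated ring carbon differ at all in this assay.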